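A few compounds are considered here, and "the series" means these few. Any claim that something is new, unique, unknown or untested is made for them only; others in the source may bear on it.

Measured so far in a functional assay on PC-3 cells (Homo sapiens) for antiproliferative activity, read by MTT assay, with a stated time of 72 h; on this read-out lower numbers stand for stronger inhibition and higher numbers for weaker inhibition
compound 1 `CCn1cc(C(CC)(CC)c2ccc(C#CC(O)(CC)CC)c(C)c2)cc1C(=O)NCC(=O)OC` gives 17500 nM
compound 2 `CCn1cc(C(CC)(CC)c2ccc(C#CC(O)(CC)CC)c(C)c2)cc1C(=O)NCCN(C)C` gives 10100 nM

Among the compounds with values here, on these numbers compound 2 is not separated from compound 1, so no ranking of the pair follows. Next comes compound 3 `CCn1cc(C(CC)(CC)c2ccc(C#CC(O)(CC)CC)c(C)c2)cc1C(=O)NCCCN(C)C` with (dimethylamino)methyl in place of dimethylamino on a saturated chain carbon, two bonds along the chain from an amide-type nitrogen as its difference from compound 2. In words, this is (dimethylamino)methyl in place of dimethylamino on a saturated chain carbon, two bonds along the chain from an amide-type nitrogen, or 2-(dimethylamino)ethyl to 3-(dimethylamino)propyl. Within the data shown here, only one measured step bears on this, and only loosely: a 1.7-fold lower number from compound 1 to compound 2 (0.24 log units; within the scatter) is a change of another kind, with (dimethylamino)methyl in place of methoxycarbonyl. Among the measured compounds shown here, no measured pair varies the chain length alone, so no step beyond the scatter is expected in this assay here. The expected change is a 1.0-fold lower number from compound 2 to compound 3 (0.00 log units; within the scatter) and no more. For compound 3 the estimated value is 10000 nM with an expected range from 5000 nM to 20000 nM in this read-out.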

Compound 3, half-maximal inhibitory concentration: 15100 nM
Estimate against measurement, compound 3: 1.5-fold (0.18 log units) below, and the stated range covers the measured number.
By their numbers in this assay, from the lowest: compounds 2, 3 and 1 (each within the scatter of the next).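

In this assay, within the data shown here, 2-(dimethylamino)ethyl to 3-(dimethylamino)propyl gives a 1.5-fold higher number from compound 2 to compound 3 (0.17 log units; within the scatter), the first measured step to vary chain length alone, and this change on a saturated chain carbon, two bonds along the chain from an amide-type nitrogen, does not separate the two compounds. The second new step, 2-(dimethylamino)ethyl in place of methoxycarbonyl, gives a 1.2-fold lower number from compound 1 to compound 3 (0.06 log units; within the scatter), so neither amine chain is separated from the methoxycarbonyl compound in this read-out. No supporting measurement bears on these results.

The compounds shown leave open whether a primary amine, a carboxylic acid, a morpholine ring or a longer chain in this side chain would move the number beyond the scatter. On these data alone, every step shown sits in this one side chain, and changes elsewhere on the shared core remain open.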